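Swapping 4-(pyrrolidin-1-yl)piperidin-1-yl for (2-hydroxyethyl)amino

This account rests on a few compounds, and the source may have more. Where it says the series, first, only, none or still open, it means among the compounds named here.

Values in a functional assay on PC-3 cells (Homo sapiens) for antiproliferative activity, read by MTT assay, with a stated time of 96 h (a higher number here means a weaker inhibitor, a lower number a stronger inhibitor), so far:
compound 1 `CC(C)N1CCN(c2ccc3nnnc(Nc4cccc(OC(F)(F)F)c4)c3n2)CC1` gives 13800 nM
compound 2 `FC(F)(F)Oc1cccc(Nc2nnnc3ccc(N4CCC(N5CCCC5)CC4)nc23)c1` gives 8160 nM
compound 3 `OCCNc1ccc2nnnc(Nc3cccc(OC(F)(F)F)c3)c2n1` has no value yet

Within the data shown here, compound 2 cannot be separated from the only other measured compound. Among the measured compounds shown here, the single measured step (a 1.7-fold lower number from compound 1 to compound 2 (0.23 log units; within the scatter)) lies within the scatter, so neither compound ranks ahead. That step put 4-(pyrrolidin-1-yl)piperidin-1-yl in place of 4-isopropylpiperazin-1-yl on an aromatic carbon. Compound 3 carries (2-hydroxyethyl)amino in place of 4-(pyrrolidin-1-yl)piperidin-1-yl on an aromatic carbon. For the measured compounds named here, the entering group has no ring, and no measured compound has a group without a ring at this place, so the one measured step bears on this change only loosely. Going by the values given here, with that step (a 1.7-fold lower number from compound 1 to compound 2 (0.23 log units; within the scatter)) as the only guide, no step beyond the scatter is expected in this assay in either direction, although two values cannot exclude a larger move. The expected change is small (a 1.2-fold higher number from compound 2 to compound 3 (0.09 log units; within the scatter)) and remains an estimate. Compound 3 is estimated at 10000 nM with a range of 3000 nM to 35000 nM expected on measurement.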

Compound 3, half-maximal inhibitory concentration: > 100000 nM
Compound 3 was reported as a limit; the forecaster's own chance of this, stated with the estimate: 15%; at least 10-fold (1.00 log units) between middle value and limit.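

In this assay compound 3 gives > 100000 nM, which is a limit of the assay and not a number. Among these compounds, the earlier pair showed only that one ring-bearing amine could replace another at this position without a step beyond the scatter (a 1.7-fold lower number from compound 1 to compound 2 (0.23 log units; within the scatter)), whereas (2-hydroxyethyl)amino, the first group without a ring here, gives an at least 12-fold higher number from compound 2 to compound 3 (1.08 log units; beyond the scatter) and, measured against 4-isopropylpiperazin-1-yl, an at least 7.2-fold higher number from compound 1 to compound 3 (0.86 log units; beyond the scatter), so the position is not indifferent to what it carries and the change goes towards a weaker inhibitor. Both steps give a minimum size only, and the full size stays unknown: the limit of > 100000 nM in this assay, at which 1 of the 3 values shown sits.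

The compounds shown do not separate the loss of the rings from the arrival of the hydroxyl, and a chain without a ring that ends in an amine, such as (2-(dimethylamino)ethyl)amino, or a ring-bearing alcohol, such as 4-hydroxypiperidin-1-yl, would bear on that. They also leave open whether any group on this aromatic carbon can give a clearly lower number than those of compound 1 and compound 2.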